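Two Limits and a Phenyl-Tetrazole Exchange

The source may report more compounds than this note shows. Statements on the series, on what has been measured and on what is new or still open speak of the compounds shown alone.

Compound 1 `CC(C)[C@H](NC(=O)COc1cccc2ccccc12)C(=O)N[C@@H](CC(=O)O)C(=O)CSc1nccn1C` gives > 200000 nM in a functional assay on Jurkat cells (Homo sapiens) for inhibition; on this read-out higher numbers stand for weaker inhibition and lower numbers for stronger inhibition; this value is a limit of the assay.
Compound 2 `CC(C)[C@H](NC(=O)COc1cccc2ccccc12)C(=O)N[C@@H](CC(=O)O)C(=O)CSc1nc[nH]n1` gives > 200000 nM; this value is also a limit of the assay.

Compound 2 therefore stands at the limit, as does compound 1 (the limit of > 200000 nM in this assay, at which 2 of the 2 values shown sit). The step that the two limits leave unreadable from compound 1 to compound 2 cannot be read in size, because both values are limits. Compound 3 `CC(C)[C@H](NC(=O)COc1cccc2ccccc12)C(=O)N[C@@H](CC(=O)O)C(=O)CSc1nnnn1-c1ccccc1` differs from compound 2 by 1-phenyl-1H-tetrazol-5-yl in place of 1H-1,2,4-triazol-3-yl on a sulfur. Going by the values given here, no measured step gives a readable size, so no direction beyond the scatter is expected. Compound 3 is estimated at 200000 nM, with a range from 50000 nM to 600000 nM. The expected step is a number no higher from compound 2 to compound 3 (the limit leaves the size open).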

Compound 3, half-maximal inhibitory concentration: 153000 nM
The estimate for compound 3 lay 1.3-fold (0.12 log units) above the measured number; measured number inside the range.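

In this assay, going by these compounds alone, compound 3 gives 153000 nM, the first value here that is a number and not a limit. Placing 1-phenyl-1H-tetrazol-5-yl on the sulfur gives an at least 1.3-fold lower number from compound 2 to compound 3 (0.11 log units; that floor lies within the scatter) and an at least 1.3-fold lower number from compound 1 to compound 3 (0.11 log units; that floor lies within the scatter), so each step is only a floor and its true size stays open. The step between the other two compounds still cannot be read, as both values are limits: the limit of > 200000 nM in this assay, at which 2 of the 3 values shown sit.

The compounds shown leave open whether the phenyl ring or the tetrazole ring accounts for these steps. Also open, going by these compounds, is how 1-methyl-1H-tetrazol-5-yl, or a phenyl ring carrying a carboxylic acid, would read on the same sulfur.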